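Cytotoxicity of naphthyl hydrazone analogues: adding two fluorines

The source may hold more compounds than are shown below. What is called first, only, known or untested is meant among the compounds shown, and "the series" means these compounds.

In an ADME assay on L6 cells (Rattus norvegicus) for cytotoxicity, read by resazurin assay, with a stated time of 72 h (a lower number here means a stronger inhibitor, a higher number a weaker inhibitor), compound 2 `N/C(CC(O)c1cccc2ccccc12)=N\N=C\c1ccccc1` gives 17000 nM. Compound 1 `N/C(CC(O)c1cccc2ccccc12)=N\N=C\c1ccc(C(F)(F)F)cc1` gives 26000 nM, and the step of a 1.5-fold lower number from compound 1 to compound 2 (0.18 log units; within the scatter) shows that hydrogen in place of trifluoromethyl changed little. Compound 3 `Cc1ccc(/C=N/N=C(\N)CC(O)c2ccc3ccccc3c2)cc1` gives 103000 nM, a number clearly apart from that of compound 2. The unmeasured compound 4 `N/C(CC(O)c1cccc2ccccc12)=N\N=C\c1ccc(F)c(F)c1` differs from compound 2 by 3,4-difluorophenyl in place of phenyl on a carbon with a double bond to nitrogen. Among the measured compounds shown here, only the step from compound 1 to compound 2 bears on an aromatic fluorine change, and it stayed within the scatter, so no step beyond the scatter is expected in this assay, perhaps a slight drift toward a higher number. For compound 4 the expected value is 22000 nM, with a range from 8000 nM to 60000 nM, meaning an expected step of a 1.3-fold higher number from compound 2 to compound 4 (0.11 log units; within the scatter).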

Compound 4, half-maximal inhibitory concentration: 17000 nM
Compound 4: the middle estimate sits 1.3-fold (0.11 log units) above what was measured; measured number inside the range.
By their numbers in this assay, from the lowest: compounds 2, 4 and 1 (each within the scatter of the next); then compound 3.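

With 3,4-difluorophenyl in place of phenyl there is no change at the digits printed from compound 2 to compound 4 (within the scatter) in this assay and so this ring carries two fluorines without any measurable shift in the reading. Compound 1 had shown only that a trifluoromethyl group on this ring stays within the scatter of hydrogen, while compound 4 shows the same for fluorines bonded directly to the ring. As far as these compounds go, whether an amine or a carboxylic acid on this phenyl ring would move the number beyond the scatter stays open. No measurement shown gives a reason for this flat result.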